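Tetrahydroquinoline anilides: acyl change on the ring nitrogen

A few compounds are considered here, and "the series" means these few. Any claim that something is new, unique, unknown or untested is made for them only; others in the source may bear on it.

Measured compounds:
compound 1 `CC(=O)N1c2ccccc2CCC1C(=O)Nc1ccccc1O` gives 65700 nM
compound 2 `O=C(Nc1ccc(C(F)(F)F)cc1)C1CCc2ccccc2N1` gives 25800 nM
compound 3 `CC(=O)N1c2ccccc2CCC1C(=O)Nc1cc(C(F)(F)F)cc(C(F)(F)F)c1` gives > 70000 nM

All three were tested in a functional assay on NCI-H23 cells (Homo sapiens) for cytotoxicity, read by sulforhodamine B assay, with a stated time of 72 h; on this read-out higher numbers stand for weaker inhibition of growth and lower numbers for stronger inhibition of growth. Compound 1 gives 65700 nM in this assay, and compound 2 gives 25800 nM. For compound 3 the value is a limit of the assay and not a number, > 70000 nM, so compound 3 stands at the weak end of the series, as noted by the limit of > 70000 nM in this assay, at which 1 of the 3 values shown sits. For the measured compounds named here, no pair of measured compounds differs in one place only, so no measured step is available to guide the next change.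

Compound 4 `O=C(Nc1cc(C(F)(F)F)cc(C(F)(F)F)c1)C1CCc2ccccc2N1C(=O)c1cccc(Cl)c1` differs from compound 3 by 3-chlorophenyl in place of methyl on a carbonyl carbon. With no measured step of this kind in the series, the direction cannot be taken from the data; the step from compound 3 to compound 4 is expected to be an at least 1.7-fold lower number from compound 3 to compound 4 (0.24 log units; that floor lies within the scatter), which is a guess with wide uncertainty. Compound 4 is therefore estimated at 40000 nM in this assay, with a range from 8000 nM to 200000 nM, and a substantial chance that the assay again reports only a limit.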

Compound 4, concentration for 50% growth inhibition: 420 nM
Beside the measured number, compound 4's estimate is 95-fold (1.98 log units) above it; the whole stated range lies above it.
By their numbers in this assay, from the lowest: compound 4; then compound 2; then compound 1. At a limit, above all of these: compound 3.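

In this assay, the position on a carbonyl carbon whose other neighbours are an amide-type nitrogen in a ring responds strongly to substitution: 3-chlorophenyl in place of methyl gives an at least 160-fold lower number from compound 3 to compound 4 (2.22 log units; beyond the scatter). For the compounds shown here, compound 1, compound 2 and compound 3 offered no comparison in one place, so this is the only measured reading of a change at this position. Compound 3 carries a limit of the assay and not a number, so the step is a floor and its full size stays unknown: the limit of > 70000 nM in this assay, at which 1 of the 4 values shown sits.

Going by these compounds alone, with 3-chlorophenyl the only aromatic group at this carbonyl carbon, the part played by the chlorine stays open. Also open, as far as these compounds go, is whether an unsubstituted phenyl, a cyclohexyl ring or an amine there would give a similarly low number, and whether the change carries over to the anilide of compound 1.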